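The source may report more compounds than this note shows. Statements on the series, on what has been measured and on what is new or still open speak of the compounds shown alone.

Compound 1 `O=c1ccoc2cc(OCc3cn(Cc4ccccc4)nn3)ccc12` opens the set. In a functional assay on MDA-MB-231 cells (Homo sapiens) for cytotoxicity, read by MTT assay, with a stated time of 48 h (on this read-out lower numbers stand for stronger inhibition and higher numbers for weaker inhibition), compound 1 gives > 100000 nM, a limit of the assay rather than a number. Going by the values given here, compound 2 `Cc1cccc(Cn2cc(COc3ccc4c(=O)ccoc4c3)nn2)c1` gives 16000 nM in this assay, the only finite value here, and the change reads an at least 6.2-fold lower number from compound 1 to compound 2 (0.79 log units; beyond the scatter). Compound 3 `O=c1ccoc2cc(OCc3cn(Cc4ccc(F)cc4)nn3)ccc12` returns > 100000 nM in this assay, again a limit. The step of an at least 6.2-fold higher number from compound 2 to compound 3 (0.79 log units; beyond the scatter) is therefore a loss, whereas a step that the two limits leave unreadable from compound 1 to compound 3 cannot be sized. Compound 3 thus stands at the limit of > 100000 nM in this assay, at which 2 of the 3 values shown sit. Among the compounds with values here, compound 4 `N#Cc1ccc(Cn2cc(COc3ccc4c(=O)ccoc4c3)nn2)cc1` differs from it by cyano in place of fluoro on an aromatic carbon; cyano is new to the set, and no measured step covers this change. With compound 3 at a limit, compound 4 is expected to move only an at least 1.1-fold lower number from compound 3 to compound 4 (0.04 log units; that floor lies within the scatter), estimated at 90000 nM (range 20000 nM to 300000 nM).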

Compound 4, half-maximal inhibitory concentration: > 100000 nM
Compound 4 ended at the assay's limit; the forecaster's own chance of this, stated with the estimate: 60%; middle value at least 1.1-fold (0.04 log units) from the limit.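

Cyano, like fluoro, leaves the series at the limit of this assay when set para to a large group, so two different groups at this place now share that outcome: the limit of > 100000 nM in this assay, at which 3 of the 4 values shown sit.

Going by these compounds alone, the one readable new step is an at least 6.2-fold higher number from compound 2 to compound 4 (0.79 log units; beyond the scatter), a second loss against the only finite value. The steps from compound 1 and from compound 3 to compound 4 join two limits and cannot be read.

Open, as far as these compounds go, is whether methyl para to a large group would give a finite value, as compound 2 does with its methyl. Also open, from the compounds shown here alone, is whether an amine or a carboxylic acid at this place would come off the limit.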